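Hydroxy on the far end of a terphenyl series

The compounds below may be only part of what the source reports. "The series", "measured", "known", "first", "only" and "open" are said of these compounds alone.

Measured in a functional assay on COLO 205 cells (Homo sapiens) for inhibition, read by sulforhodamine B assay; a higher number here means a weaker inhibitor of growth, a lower number a stronger inhibitor of growth:
- compound 1 `FC(F)(F)Oc1ccc(-c2ccc(-c3ccc(-c4nc5ccccc5[nH]4)cc3)cc2)cc1`: 100000 nM
- compound 2 `COc1ccc(-c2ccc(-c3ccc(-c4nc5ccccc5[nH]4)cc3)cc2)cc1`: 45200 nM
- compound 3 `Clc1cccc(-c2ccc(-c3ccc(-c4nc5ccccc5[nH]4)cc3)cc2)c1`: 100000 nM

Compound 2 holds the lowest number of the three, at 45200 nM, and compound 1 and compound 3 show the same value. Compound 4 `COc1ccc(-c2ccc(-c3ccc(-c4nc5c(O)cccc5[nH]4)cc3)cc2)cc1` is the next case, with hydroxy in place of hydrogen on an aromatic carbon.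

Two measured steps start or end at compound 2. The first is a 2.2-fold lower number from compound 1 to compound 2 (0.34 log units; beyond the scatter), with methyl in place of trifluoromethyl on an oxygen. The second is a 2.2-fold higher number from compound 2 to compound 3 (0.34 log units; beyond the scatter), with 3-chlorophenyl in place of 4-methoxyphenyl. Both are modest, but neither changes the carbon that carries the new hydroxy, so they offer only a rough guide to size and none to direction. No measured change in this series occurs at that place.

The best expectation in this assay is therefore no step beyond the scatter, with real uncertainty on either side. The estimate for compound 4 is 40000 nM, with an expected range from 10000 nM to 100000 nM. This estimate means an expected 1.1-fold lower number from compound 2 to compound 4 (0.05 log units; within the scatter).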

Compound 4, concentration for 50% growth inhibition: 1630 nM
The estimate for compound 4 lay 25-fold (1.39 log units) above the measured number; measured number below the stated range.
By their numbers in this assay, from the lowest: compound 4; then compound 2; then compounds 1 and 3 (each within the scatter of the next).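

In this assay the change from 1H-benzimidazol-2-yl to 4-hydroxy-1H-benzimidazol-2-yl gives a 28-fold lower number from compound 2 to compound 4 (1.44 log units; beyond the scatter) as a large step, while the earlier changes elsewhere on the molecule gave only modest steps, namely a 2.2-fold lower number from compound 1 to compound 2 (0.34 log units; beyond the scatter) and a 2.2-fold higher number from compound 2 to compound 3 (0.34 log units; beyond the scatter) in this series. This aromatic carbon of the fused system, left unchanged across compound 1, compound 2 and compound 3, is therefore the most responsive place among the compounds shown, and compound 4 at 1630 nM in the same assay holds the lowest number of the four. No supporting measurement bears on why hydroxy has this effect here, so the step stands as an observation only.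

As far as these compounds go, whether the gain belongs to hydroxy itself remains open, since methoxy, an amine or fluorine on the same carbon would separate that group from any other substituent at this place. From the compounds shown here alone, it also remains open whether the same hydroxy gives a step of similar size on the trifluoromethoxy partner of compound 1 or the 3-chlorophenyl partner of compound 3, and how other carbons of the same ring respond.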